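Acetyl to benzoyl on compound 1

This account rests on a few compounds, and the source may have more. Where it says the series, first, only, none or still open, it means among the compounds named here.

Compound 1 `CC(=O)Oc1ccc(Cn2ccnc2)c2cccnc12`: 28500 nM
Compound 2 `CC(C)(C)OC(=O)Oc1ccc(Cn2c(-c3cscn3)nc3ccccc32)c2cccnc12`: "not determined" (no result reported)
Compound 3 `Oc1ccc(Cn2nnc3ccccc32)c2cccnc12`: 1000 nM

In a functional assay on MV4-11 cells (Homo sapiens) for antiproliferative activity, read by luminescence, with a stated time of 72 h (on this read-out higher numbers stand for weaker inhibition and lower numbers for stronger inhibition), compound 1 gives 28500 nM, the higher of the two numbers available, while compound 3 gives 1000 nM, a gap beyond the scatter. Going by the values given here, compound 2 has no result, and no two measured compounds differ in one place, so no measured step bears on this change. Compound 4 `O=C(Oc1ccc(Cn2ccnc2)c2cccnc12)c1ccccc1` carries phenyl in place of methyl on a carbonyl carbon, acetyl to benzoyl: phenyl in place of methyl on a carbonyl carbon. A small move toward a lower number is expected in this assay, possibly none beyond the scatter. The estimated step is a 1.4-fold lower number from compound 1 to compound 4 (0.15 log units; within the scatter). For compound 4 the expected value is 20000 nM, with an estimated range of 6000 nM to 60000 nM.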

Compound 4, half-maximal inhibitory concentration: 9000 nM
For compound 4 the middle estimate is 2.2-fold (0.35 log units) above the measured one, within the range that was stated.
By their numbers in this assay, from the lowest: compound 3; then compound 4; then compound 1.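

In this assay, going by these compounds alone, the change from acetyl to benzoyl gives a 3.2-fold lower number from compound 1 to compound 4 (0.50 log units; beyond the scatter) and is the first step at a single place that can be read in this set. It shows that the carbonyl carbon accepts phenyl in place of methyl, and that the larger group goes with a modestly lower number. Nothing measured here accounts for this step.

As far as these compounds go, whether a longer chain, a pyridyl ring or an amine on the same carbonyl carbon would lower the number further remains open. So does whether the step from acetyl to benzoyl would carry over to a core such as that of compound 3.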